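From Chloro to Iodo on the Shared Core

The compounds below may be only part of what the source reports. "The series", "measured", "known", "first", "only" and "open" are said of these compounds alone.

Compound 1, `C[C@@H](NC(=O)Nc1ccccc1C(F)(F)F)c1ccccc1`: 99%
Compound 2, `C[C@@H](NC(=O)Nc1ccccc1Cl)c1ccccc1`: 101%

In an ADME assay on the whole organism with Oryza sativa as the target, tested at 0.1 uM (a higher number here means a weaker effect of the compound at the concentration tested, a lower number a stronger effect), compound 1 gives 99%, and in the same assay compound 2 gives 101%. Among the measured compounds shown here, the one step between measured compounds is a number 2 percentage points higher from compound 1 to compound 2 (within the scatter). Compound 2 therefore stands highest of the two numbers, but its nearest neighbour, compound 1, lies within the scatter of it, a gap that says nothing about order.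

Compound 3, `C[C@@H](NC(=O)Nc1ccccc1I)c1ccccc1`, has not yet been measured in this assay. Its difference from compound 2 is iodo in place of chloro on an aromatic carbon. For the measured compounds named here, the only measured step that bears on this change is the one from compound 1 to compound 2, which also swaps one group on the same aromatic carbon, and that step was within the scatter. On that basis no step beyond the scatter is expected in this assay for compound 3 in either direction, that is, a step of a number 1 percentage points lower from compound 2 to compound 3 (within the scatter). Compound 3 is accordingly estimated to give 100%, with a range from 90% to 110%.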

Compound 3, a percentage reported as activity, at one concentration (the size of the read-out at that concentration, not a potency): 100%
Beside the measured number, compound 3's estimate shows no gap at the digits printed, within the range that was stated.
By their numbers in this assay, from the lowest: compounds 1, 3 and 2 (each within the scatter of the next).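

In this assay, iodo in place of chloro gives a number 1 percentage points lower from compound 2 to compound 3 (within the scatter), and iodo in place of trifluoromethyl gives a number 1 percentage points higher from compound 1 to compound 3 (within the scatter). The aromatic carbon that varies across the shared core has now carried three different groups, and every step among them lies within the scatter, so the read-out at this one concentration does not separate trifluoromethyl, chloro and iodo; what was a single pair with compound 1 and compound 2 now holds across a set of three. No separate measurement on these compounds bears on why the three groups read alike.

The compounds shown leave open whether a group of another kind on this aromatic carbon, such as an amine, a hydroxyl, a carboxylic acid or a longer chain, would give a step beyond the scatter, since only trifluoromethyl, chloro and iodo have been seen there. They also leave open whether a change elsewhere on the shared core, for instance at the urea or on the other aromatic ring, would move the number, and whether these three compounds would stay together at another concentration.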